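Cytotoxicity notes on a nitro-to-amino pair

A few compounds are considered here, and "the series" means these few. Any claim that something is new, unique, unknown or untested is made for them only; others in the source may bear on it.

Measured in an ADME assay on Vero cells (Chlorocebus sabaeus) for cytotoxicity; a lower number here means that less compound is tolerated, a higher number that more compound is tolerated:

- compound 1 `Nc1ccc(-c2nc3cc(Cl)c(Cl)cc3[nH]2)cc1`: >= 100000 nM, a limit of the assay
- compound 2 `O=[N+]([O-])c1ccc(-c2nc3cc(C(F)(F)F)ccc3n2C2CCCCC2)cc1`: > 100000 nM, a limit of the assay
- compound 3 `O=[N+]([O-])c1ccc(-c2nc3cc(Cl)c(Cl)cc3[nH]2)cc1`: >= 100000 nM, a limit of the assay

All three values in this assay are limits and not numbers. Compound 3 and compound 1 differ by amino in place of nitro on an aromatic carbon, and the step that the two limits leave unreadable from compound 3 to compound 1 cannot be read because both ends are limits. Among the values shown, the limit of >= 100000 nM in this assay, at which 2 of the 3 values shown sit, and (the limit of > 100000 nM in this assay, at which 1 of the 3 values shown sits); nothing here separates the three compounds.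

Compound 4 `Nc1ccc(-c2nc3cc(C(F)(F)F)ccc3n2C2CCCCC2)cc1` is not yet measured. It differs from compound 2 by amino in place of nitro on an aromatic carbon, which is the same change as that from compound 3 to compound 1, made at a place described in the same words. The difference between the core of compound 2 and the core of compound 3 is not broken down here.

Within the data shown here, the one earlier instance of this change, from compound 3 to compound 1, gives no readable size in this assay. The expectation for compound 4 therefore rests only on compound 2 sitting at > 100000 nM and on compound 1 sitting at >= 100000 nM after the same change. The step from compound 2 to compound 4 is expected to be small, a number no higher from compound 2 to compound 4 (the limit leaves the size open), and most likely to leave the value at a limit again. For compound 4 the estimate in this assay is 100000 nM, with a range from 50000 nM to 300000 nM.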

Compound 4, half-maximal cytotoxic concentration: > 100000 nM
Compound 4 was reported as a limit; the forecaster's own chance of this, stated with the estimate: 85%; the middle value sits exactly at the limit.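

Among these compounds, compound 2 and compound 4 both stand at limits and not numbers in this assay, and the step between them cannot be read, so this result adds no new step. The compounds shown leave open whether amino in place of nitro changes the cytotoxic concentration at all, and what number any of the four compounds would give in this assay.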